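The source may hold more compounds than are shown below. What is called first, only, known or untested is meant among the compounds shown, and "the series" means these compounds.

Compound 1 `COC(=O)c1c(O)c2ccccc2n(C)c1=O` — 72.4%
Compound 2 `COC(=O)c1c(O)c2ccccc2n(-c2ccccc2)c1=O` — 100%

Among the compounds with values here, in an assay on isolated protein for inhibition of seed linoleate 13S-lipoxygenase-1 (Glycine max), tested at 0.1 mM (a higher number here means more inhibition at the concentration tested (going by the name of the read-out), a lower number less inhibition), compound 1 stands lowest of the two measured compounds, and the one measured step, a number 27.6 percentage points higher from compound 1 to compound 2 (beyond the scatter), concerns a change on the aromatic nitrogen. Compound 3 `Cn1c(=O)c(C(=O)NCCN)c(O)c2ccccc21` differs from compound 1 at another place: (2-aminoethyl)amino in place of methoxy on a carbonyl carbon. Within the data shown here, no measured step touches a change at this carbonyl carbon, so nothing here shows how such a change moves the inhibition. Compound 3 is therefore expected to stay near compound 1, with a step of a number 7.4 percentage points lower from compound 1 to compound 3 (within the scatter) and no clear direction. Compound 3 is estimated at 65%, within 35% to 95%.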

Compound 3, a percentage reported as inhibition, at one concentration (the size of the read-out at that concentration, not a potency): 99.5%
The estimate for compound 3 lay 34.5 percentage points below the measured number, outside the stated range (above it).
By their numbers in this assay, from the lowest: compound 1; then compounds 3 and 2 (each within the scatter of the next).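

Putting (2-aminoethyl)amino in place of methoxy on a carbonyl carbon gives a number 27.1 percentage points higher from compound 1 to compound 3 (beyond the scatter) in this assay. Within the data shown here, this shows that the carbonyl carbon, which no earlier step touched, is a second place where a single change to compound 1 raises the inhibition. No available evidence explains this step.

The compounds shown leave open whether the amine in the chain is needed, which a simple ethylamide, a longer aminoalkyl chain or a carboxylic acid at this carbonyl carbon would address. They also leave open how this change behaves with phenyl on the aromatic nitrogen.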